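Smaller branched alkyl on the cyanoguanidine nitrogen

The compounds below may be only part of what the source reports. "The series", "measured", "known", "first", "only" and "open" are said of these compounds alone.

Compound 1 `CCC(CC)(CC)/N=C(\NC#N)Nc1cc(Cl)cc(C#N)c1` is described by a single assay, a functional assay with Cavia porcellus as the target (a lower number here means that less compound is needed, a higher number that more compound is needed for the effect), and there it gives only a limit: > 1 uM. Its close analogue compound 2 `CCC(CC)(CC)/N=C(\NC#N)Nc1cc(Cl)cc(Cl)c1` sits at the same kind of boundary, with > 1 uM in this assay. Compound 3 `CCC(C)(C)/N=C(\NC#N)Nc1cc(F)cc(Br)c1`, which carries a different aryl substitution and a shorter alkyl group, gives a measured number of 0.016 uM in this assay. For the measured compounds named here, the only step among the measured compounds, a step that the two limits leave unreadable from compound 1 to compound 2, stays unreadable, as the limit of > 1 uM in this assay, at which 2 of the 3 values shown sit, shows, and it concerns the aryl group, not the alkyl side.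

Compound 4 `CC(C)C(C)(C)/N=C(\NC#N)Nc1cc(Cl)cc(C#N)c1` keeps the chloro and cyano aryl of compound 1 and changes the other end: 1,1,2-trimethylpropyl in place of 1,1-diethylpropyl on a double-bonded nitrogen. Going by the values given here, no measured step addresses this kind of change, so its size and direction in this assay cannot be read from the data. Among the compounds with values here, compound 3, with a shorter alkyl group and a measured value of 0.016 uM, is the only indication that compounds of this core can reach a measured number in this assay, but its aryl group also differs, so the two changes cannot be separated. The estimate for compound 4 therefore stays broad: an expected value of 0.5 uM in this assay, between 0.05 uM and 5 uM. That corresponds to an expected step of an at least 2.0-fold lower number from compound 1 to compound 4 (0.30 log units; that floor lies within the scatter), read against a limit rather than a number.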

Compound 4, concentration for half-maximal effect: 0.19 uM
For compound 4 the middle estimate is 2.6-fold (0.42 log units) above the measured one; low and high end bracket the measured number.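

With the chloro and cyano aryl group held fixed, 1,1,2-trimethylpropyl in place of 1,1-diethylpropyl on a double-bonded nitrogen gives, in this assay, an at least 5.2-fold lower number from compound 1 to compound 4 (0.72 log units; beyond the scatter). This is the first readable step among the compounds shown, and it establishes that the alkyl group alone can move the result beyond the scatter, which the earlier comparison on the aryl side could not show. The entering group has 6 heavy atoms against 7 in the leaving one, but the true size of the step remains unknown, as compound 1 gives only a limit and the step is therefore a floor: the limit of > 1 uM in this assay, at which 2 of the 4 values shown sit.

From the compounds shown here alone, whether the same alkyl change would have a similar effect with another aryl group stays open, as does how the shorter alkyl group of compound 3 would compare with 1,1,2-trimethylpropyl on the chloro and cyano aryl group. The compounds shown also leave open what a cyclohexyl group, or an alkyl chain ending in a hydroxyl group or an amine, would give on this nitrogen.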